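Exchanging the Benzyl Group on a Shared Pyridinone Core

The source may report more compounds than this note shows. Statements on the series, on what has been measured and on what is new or still open speak of the compounds shown alone.

Within the data shown here, compound 3 `O=c1ccc(-c2ccc3cn[nH]c3c2)cn1Cc1ccccc1Cl` stands second highest of the three numbers measured so far in an assay for inhibition of MAP kinase-interacting serine/threonine-protein kinase 1 (Homo sapiens), read by luminescence and ADP-Glo, with a stated time of 2 h (on this read-out higher numbers stand for weaker inhibition and lower numbers for stronger inhibition), where compound 3 gives 80 nM. Compound 1 `Nc1cccc(Cn2cc(-c3ccc4cn[nH]c4c3)ccc2=O)c1` gives 287 nM, while compound 2 `Nc1n[nH]c2cc(-c3ccc(=O)n(Cc4cccc(F)c4)c3)ccc12` gives 19 nM. Among the measured compounds shown here, the single measured step at the same place, a 3.6-fold lower number from compound 1 to compound 3 (0.55 log units; beyond the scatter), shows that this benzyl position can move the number by a modest amount. Compound 4 `O=c1ccc(-c2ccc3cn[nH]c3c2)cn1Cc1cccc(F)c1` differs from compound 3 by 3-fluorophenyl in place of 2-chlorophenyl on a saturated chain carbon bound to an aromatic nitrogen. For the measured compounds named here, no measured pair exchanges these two groups directly, and compound 2 carries the 3-fluorophenyl but also differs elsewhere, so its value bears only indirectly. The step of a 1.3-fold lower number from compound 3 to compound 4 (0.12 log units; within the scatter) is therefore expected to be small, within or near the scatter. For compound 4 the estimate in this assay is 60 nM, ranging from 20 nM to 180 nM.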

Compound 4, half-maximal inhibitory concentration: 74 nM
Beside the measured number, compound 4's estimate is 1.2-fold (0.09 log units) below it; the range from low to high includes it.
By their numbers in this assay, from the lowest: compound 2; then compounds 4 and 3 (each within the scatter of the next); then compound 1.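

Putting 3-fluorophenyl in place of 2-chlorophenyl gives a 1.1-fold lower number from compound 3 to compound 4 (0.03 log units; within the scatter) and so does not separate these two groups in this assay. Fluoro in place of amino on an aromatic carbon of this group gives a 3.9-fold lower number from compound 1 to compound 4 (0.59 log units; beyond the scatter) and adds a second halogen-bearing compound that stands apart from the amino-bearing one. With the 3-fluorophenyl held fixed, hydrogen in place of amino on an aromatic carbon outside this position gives a 3.9-fold higher number from compound 2 to compound 4 (0.59 log units; beyond the scatter) and shows that the number also moves away from the benzyl position.

Nothing given here accounts for these steps. From the compounds shown here alone, whether a carboxylic acid or a methoxy group on the phenyl ring, or a longer chain to it, would leave the number unchanged remains open.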